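Swapping the Aryl Group on the Shared Core

This account rests on a few compounds, and the source may have more. Where it says the series, first, only, none or still open, it means among the compounds named here.

Measured so far:
Compound 1 `COc1ccc(-c2c(S(=O)(=O)c3ccc(C)c(F)c3)cnc3c(F)cccc23)cc1` gives 3.27 mL/min in an ADME assay on microsomes from liver (Homo sapiens) for metabolic stability, tested at 2.5 uM; a lower number here means slower removal, a higher number faster removal of the compound.
Compound 2 `COc1ccc(-c2c(S(=O)(=O)c3ccc(OC)cc3)cnc3c(F)cccc23)cc1` gives 2.12 mL/min.
Compound 3 `O=S(=O)(c1ccc(F)c(F)c1)c1cnc2c(F)cccc2c1-c1ccccc1F` gives 1.39 mL/min.

Compound 3 has the lowest of the three numbers; its gap to compound 2 is within the scatter, while compound 1 sits beyond it. Compound 4 `COc1ccc(-c2c(S(=O)(=O)c3ccc(F)c(F)c3)cnc3c(F)cccc23)cc1` differs from compound 3 in one place: 4-methoxyphenyl in place of 2-fluorophenyl on an aromatic carbon. Among the compounds with values here, no measured step touches this position; the only step, a 1.5-fold lower number from compound 1 to compound 2 (0.19 log units; within the scatter), changes the group on the sulfonyl sulfur and lies within the scatter. Compounds 1 and 2 both carry 4-methoxyphenyl here and give higher numbers than compound 3, so compound 4 is expected to rise modestly, a 1.5-fold higher number from compound 3 to compound 4 (0.18 log units; within the scatter). Compound 4 is estimated at 2.1 mL/min, between 1.1 mL/min and 4 mL/min.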

Compound 4, intrinsic clearance in a liver preparation (reported as CLH), per the amount of preparation that the assay uses: 2.12 mL/min
Compound 4: middle estimate off by 1.0-fold (0.00 log units), on the low side; the measured number falls inside the stated range.
By their numbers in this assay, from the lowest: compounds 3, 2, 4 and 1 (each within the scatter of the next, the first and the last beyond it).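

In this assay the aromatic carbon opposite the ring nitrogen now has its first measured step, a 1.5-fold higher number from compound 3 to compound 4 (0.18 log units; within the scatter), so 4-methoxyphenyl and 2-fluorophenyl are not separated at this position. Changes on the sulfonyl side are not separated either: the step is no change at the digits printed from compound 2 to compound 4 (within the scatter) for 3,4-difluorophenyl in place of 4-methoxyphenyl, and a 1.5-fold lower number from compound 1 to compound 4 (0.19 log units; within the scatter) for fluoro in place of methyl. Nothing on hand offers a reason for these results. Still open, from the compounds shown here alone, is whether an amine or a carboxylic acid on the aryl group at this position would give a step beyond the scatter.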